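The source may report more compounds than this note shows. Statements on the series, on what has been measured and on what is new or still open speak of the compounds shown alone.

Of the compounds shown here, three with a common sulfonamide core have been measured in a functional assay on DLD-1 cells (Homo sapiens) for antiproliferative activity, read by CellTiter-Glo, with a stated time of 72 h; a higher number here means a weaker inhibitor, a lower number a stronger inhibitor. Compound 1 `CC1CCN(C2CCN(S(=O)(=O)c3cccc(Br)c3)CC2)CC1` gives 3.2 nM, and it stands lowest of the three. Compound 2 `COc1ccccc1-c1cccc(S(=O)(=O)N2CCC(N3CCC(C)CC3)CC2)c1` gives 21 nM. Compound 3 `Cc1cc(C)c(S(=O)(=O)N2CCN(C3CN4CCC3CC4)CC2)c(C)c1` gives 84 nM; it differs from compound 1 in more than one place. Going by the values given here, the one single-point step among them is the replacement of the bromo substituent with a 2-methoxyphenyl group, which produced a 6.6-fold higher number from compound 1 to compound 2 (0.82 log units; beyond the scatter).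

The next compound, compound 4 `CCc1ccc(S(=O)(=O)N2CCC(N3CCC(C)CC3)CC2)cc1`, is related to compound 1 by a change on the sulfonyl sulfur: 4-ethylphenyl in place of 3-bromophenyl on a sulfonyl sulfur. Among the compounds with values here, no measured step alters the aryl group in exactly this way; the nearest comparison is the step from compound 1 to compound 2, where swapping the substituent on the same ring raised the number modestly. Within the data shown here, with only that step as a guide, and with compound 1 already the lowest value seen, the expectation is a move towards a higher number, of modest size, rather than an improvement, though a result within the scatter of compound 1 cannot be ruled out. Compound 4 is therefore expected to show a 3.1-fold higher number from compound 1 to compound 4 (0.49 log units; beyond the scatter), and its estimated value in this assay is 10 nM, within a range of 3 nM to 40 nM.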

Compound 4, half-maximal inhibitory concentration: > 5000 nM
Compound 4: only a limit was reported (the forecaster's own chance of this, stated with the estimate: 2%); middle value at least 500-fold (2.69 log units) away from the limit.
By their numbers in this assay, from the lowest: compound 1; then compound 2; then compound 3. At a limit, above all of these: compound 4.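

Going by these compounds alone, putting 4-ethylphenyl in place of 3-bromophenyl on a sulfonyl sulfur brings an at least 1500-fold higher number from compound 1 to compound 4 (3.19 log units; beyond the scatter), a large step, whereas the only earlier change on this aryl group brought a 6.6-fold higher number from compound 1 to compound 2 (0.82 log units; beyond the scatter), a modest one. In this assay the reading for compound 4, > 5000 nM, is a limit of the assay and not a number. The group that leaves and the group that enters each hold one six-membered aromatic ring of carbon only, with no hydrogen-bond donors, no hydrogen-bond acceptors and no net charge, so this large step comes with no difference in any of those counts.

The compounds shown do not separate the loss of the bromo from the arrival of the ethyl, nor either of these from the different place of the substituent on the ring, since all of them changed together in this single step. Also open, from the compounds shown here alone, is how a plain phenyl, or a chloro, methoxy or methyl group on this ring, would read in this assay with the rest of compound 1 kept unchanged.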